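The compounds below may be only part of what the source reports. "The series", "measured", "known", "first", "only" and "open" are said of these compounds alone.

Series notes. Compound 1 `O=C(CCNC(=O)c1cc(-c2ccc(F)cc2)[nH]n1)NO` carries a short saturated chain ending in a hydroxycarbamoyl group on the shared core. In an assay on cells for inhibition of protein deacetylase HDAC6 (Homo sapiens), read by fluorescence, with stated times of 15 min and 60 min (on this read-out higher numbers stand for weaker inhibition and lower numbers for stronger inhibition), compound 1 gives only a limit, > 5000 nM, and no number. Compound 2 `O=C(NO)c1ccc(Cn2nc(Cc3ccccc3)cc2-c2ccc(F)cc2)cc1`, built on a different core, gives 420 nM in this assay. Among the compounds with values here, no pair of measured compounds differs in one place, so no measured step is at hand; what the two values show is that compound 1 sits at the limit of > 5000 nM in this assay, at which 1 of the 2 values shown sits, while compound 2 is well inside the measured range.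

Compound 3 `O=C(CCCCCCNC(=O)c1cc(-c2ccc(F)cc2)[nH]n1)NO` is not yet measured. It differs from compound 1 as follows: 4-(hydroxycarbamoyl)butyl in place of hydroxycarbamoyl on a saturated chain carbon, two bonds along the chain from an amide-type nitrogen. The chain between the amide-type nitrogen and the hydroxycarbamoyl end is thus longer. Since the value of compound 1 is a limit, the size of the step cannot be anchored on a number. The estimated step of an at least 5.0-fold lower number from compound 1 to compound 3 (0.69 log units; beyond the scatter) is expected to be a gain in inhibition beyond the usual scatter. Compound 3 is expected to give 1000 nM in this assay, with a range from 150 nM to 6000 nM.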

Compound 3, half-maximal inhibitory concentration: 22 nM
Compound 3: middle estimate off by 45-fold (1.66 log units), on the high side, and the stated range ends above it.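

On the shared core, the length of the chain carrying the hydroxycarbamoyl end now proves to matter strongly: 4-(hydroxycarbamoyl)butyl in place of hydroxycarbamoyl on a saturated chain carbon, two bonds along the chain from an amide-type nitrogen, gives an at least 220-fold lower number from compound 1 to compound 3 (2.35 log units; beyond the scatter) in this assay. Compound 1 gives a limit and not a number, so this step fixes only the least size of the change: the limit of > 5000 nM in this assay, at which 1 of the 3 values shown sits. The earlier compounds shown here offered no measured step, whereas this pair shows that the longer chain alone, with the hydroxycarbamoyl end and the rest of the structure unchanged, takes the series from the limit into the measured range.

Within the data shown here, with only two chain lengths on this core, the shape of the dependence on length stays open: a chain of intermediate length or a longer chain could bring the number lower still or raise it again. Also open, on these data alone, is whether the gain depends on the hydroxycarbamoyl end itself, which a carboxylic acid or an amine at the end of the chain of compound 3 would test.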